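Swapping One Aromatic Substituent in a Rat Whole-Organism Series

A few compounds are considered here, and "the series" means these few. Any claim that something is new, unique, unknown or untested is made for them only; others in the source may bear on it.

Measured compounds:
compound 1 `O=C(/C=C/c1ccncc1)c1cccc(C(F)(F)F)c1` gives 41000 nM
compound 2 `COc1cc(C(O)/C=C/c2ccncc2)cc(OC)c1OC` gives a limit, > 100000 nM
compound 3 `O=C(c1ccccc1)c1ccccc1-c1cccnc1` gives a limit, > 100000 nM

For the measured compounds named here, in a functional assay with Rattus norvegicus as the target (on this read-out lower numbers stand for stronger inhibition and higher numbers for weaker inhibition), compound 1 is the only compound with a number at all. The other two sit at the limit of > 100000 nM in this assay, at which 2 of the 3 values shown sit, so nothing can be said about how compound 2 or compound 3 compares with compound 1 beyond the fact that each of them reports only a limit.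

Compound 4 `CN(C)c1cccc(C(=O)/C=C/c2ccncc2)c1` differs from compound 1 in one place: dimethylamino in place of trifluoromethyl on an aromatic carbon. Going by the values given here, no pair of measured compounds differs in a single place, so there is no measured step that this change can be set against.

With nothing to calibrate against, compound 4 is expected to stay close to compound 1 in this assay, and the step of a 1.1-fold higher number from compound 1 to compound 4 (0.04 log units; within the scatter) is estimated to lie within the scatter, with no clear direction. Compound 4 is estimated at 45000 nM, between 12000 nM and 160000 nM, with a fair chance that only a limit is reported.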

Compound 4, half-maximal inhibitory concentration: 19000 nM
The estimate for compound 4 lay 2.4-fold (0.37 log units) above the measured number; the measured number falls inside the stated range.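

In this assay, for the compounds shown here, the aromatic carbon meta to a large group responds to substitution: dimethylamino in place of trifluoromethyl gives a 2.2-fold lower number from compound 1 to compound 4 (0.33 log units; beyond the scatter), the first step that can be read. Trifluoromethyl is therefore not required at this position for a measured number on this read-out, and the shared core keeps its inhibition with the replacement in place. Compound 2 and compound 3 give no second step to set this one against, since neither differs from another compound in one place and each reports only a limit: the limit of > 100000 nM in this assay, at which 2 of the 4 values shown sit.

From the compounds shown here alone, whether the lower number belongs to dimethylamino specifically or would also appear with other groups at this position remains open. A primary amine or a carboxylic acid on the same aromatic carbon would be needed to tell, and a single step sets no trend.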